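The compounds below may be only part of what the source reports. "The series", "measured", "known", "first", "only" and "open" are said of these compounds alone.

Working notes on the series. Compound 1 `CCCOC(=O)N[C@H](C)c1nc2ccc(F)cc2s1` gives 4.56 in a physicochemical assay for lipophilicity, using the shake flask method, measured as octanol-water partition, with a stated time of 15 min; a higher number here means a more lipophilic compound, a lower number a more polar compound; compound 2 `CC(C)COC(=O)N[C@H](C)c1nc2ccc(F)cc2s1` gives 4.24; compound 3 `C[C@@H](NC(=O)OC(C)(C)C)c1nc2ccc(F)cc2s1` gives 4.41. Compound 3 stands second highest of the three, with both gaps inside the scatter: a number 0.15 log units lower from compound 1 to compound 3 (within the scatter) and a number 0.17 log units higher from compound 2 to compound 3 (within the scatter). Going by the values given here, the one step beyond the scatter, a number 0.32 log units lower from compound 1 to compound 2 (beyond the scatter), concerns methyl in place of hydrogen and not the oxygen next to a carbonyl group. Compound 4 `C[C@@H](NC(=O)OCCBr)c1nc2ccc(F)cc2s1` carries 2-bromoethyl in place of tert-butyl on an oxygen next to a carbonyl group. The two exchanges already seen at that oxygen moved this assay only within the scatter, so a small step is expected here as well, if anything downward, a number 0.26 log units lower from compound 3 to compound 4 (within the scatter). Compound 4 is estimated at 4.15, in the range 3.75 to 4.55.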

Compound 4, partition coefficient: 3.17
Estimate against measurement, compound 4: 0.98 log units above; the whole stated range lies above it.
By their numbers in this assay, from the lowest: compound 4; then compounds 2, 3 and 1 (each within the scatter of the next, the first and the last beyond it).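

On an oxygen next to a carbonyl group, this position can shift this assay much further than the earlier exchanges there showed, with 2-bromoethyl in place of tert-butyl giving a number 1.24 log units lower from compound 3 to compound 4 (beyond the scatter). The shift also holds against the other two groups (a number 1.07 log units lower from compound 2 to compound 4 (beyond the scatter)), and the closest comparison, bromo in place of methyl at the chain end, gives the largest step (a number 1.39 log units lower from compound 1 to compound 4 (beyond the scatter)). Nothing available accounts for a step of this size. On these data alone, whether 2-chloroethyl, 2-fluoroethyl or 2-hydroxyethyl would follow 2-bromoethyl remains open, as does whether a longer chain ending in bromo would.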